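Hydroxy for methoxymethyl on the amine side chain

The compounds below may be only part of what the source reports. "The series", "measured", "known", "first", "only" and "open" are said of these compounds alone.

Going by the values given here, compound 2 `COCCCNC(=C\C(=O)/C=C/c1ccc(O)cc1)/C=C/c1ccc(O)cc1` stands as the only numbered value in a toxicity assay on EA.hy 926 cells (Homo sapiens) for cytotoxicity, read by MTT assay, with a stated time of 48 h (on this read-out higher numbers stand for weaker inhibition and lower numbers for stronger inhibition), where compound 2 gives 81900 nM. Compound 1 `COc1cc(/C=C/C(=O)/C=C(/C=C/c2ccc(O)c(OC)c2)NCCO)ccc1O` gives > 100000 nM in this assay, a limit of the assay rather than a number. Compound 3 `O=C(/C=C(/C=C/c1ccc(O)cc1)NCCO)/C=C/c1ccc(O)cc1` differs from compound 2 by hydroxy in place of methoxymethyl on a saturated chain carbon, two bonds along the chain from an amine nitrogen. Among the compounds with values here, no step between measured compounds is available, so the size of this change is untested; given that compound 1 sits at the limit of > 100000 nM in this assay, at which 1 of the 2 values shown sits, the step of a 1.2-fold higher number from compound 2 to compound 3 (0.09 log units; within the scatter) is expected to be small and toward weaker inhibition, if beyond the scatter at all. Compound 3 is therefore estimated at 100000 nM, within 40000 nM to 250000 nM, with a fair chance that this assay again reports only a limit.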

Compound 3, half-maximal inhibitory concentration: 50200 nM
The estimate for compound 3 lay 2.0-fold (0.30 log units) above the measured number; measured number inside the range.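

Replacing methoxymethyl with hydroxy on the saturated chain carbon gives a 1.6-fold lower number from compound 2 to compound 3 (0.21 log units; within the scatter) in this assay, so this change does not separate the two compounds on this read-out. Compound 3, like compound 2, gives a measured number rather than a limit. Compound 1 alone remains at a limit of the assay: the limit of > 100000 nM in this assay, at which 1 of the 3 values shown sits.

The compounds shown leave open whether a terminal amine, a carboxylic acid or a longer chain at this position would move the number beyond the scatter. They also do not show whether any change here would matter on the core of compound 1.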